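From 2-fluorophenyl to 2,4-dichlorophenyl, read through assay limits

This account rests on a few compounds, and the source may have more. Where it says the series, first, only, none or still open, it means among the compounds named here.

Measured in a physicochemical assay for solubility (on this read-out higher numbers stand for higher solubility and lower numbers for lower solubility), each value a limit and not a number:
- compound 1 `O=C(O)c1ccc(C(=O)/C(=C\c2ccc(Cl)c([N+](=O)[O-])c2)SCc2ccc(F)cc2)cc1`: < 1000 ug/mL
- compound 2 `O=C(O)c1ccc(C(=O)/C(=C\c2ccc(Cl)c([N+](=O)[O-])c2)SCc2ccc(Br)cc2)cc1`: < 1000 ug/mL
- compound 3 `O=C(O)c1ccc(C(=O)/C(=C\c2ccc(Cl)c([N+](=O)[O-])c2)SCc2ccccc2F)cc1`: < 1000 ug/mL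

All the measured compounds sit together at the limit of < 1000 ug/mL in this assay, at which 3 of the 3 values shown sit. Compound 3 therefore has no exact number, only the limit < 1000 ug/mL.

Compound 4 `O=C(O)c1ccc(C(=O)/C(=C\c2ccc(Cl)c([N+](=O)[O-])c2)SCc2ccc(Cl)cc2Cl)cc1` differs from it by 2,4-dichlorophenyl in place of 2-fluorophenyl on a saturated chain carbon bound to a sulfur.

Two measured steps change that same place: a step that the two limits leave unreadable from compound 1 to compound 3, and a step that the two limits leave unreadable from compound 2 to compound 3. A third is a step that the two limits leave unreadable from compound 1 to compound 2. None has a readable size, so they give no direction, and no readable shift is expected in this assay. The expected step is a step that the limit leaves unreadable from compound 3 to compound 4.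

For compound 4 the estimate is 300 ug/mL, with an expected range from 30 ug/mL to 1000 ug/mL.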

Compound 4, solubility: < 1000 ug/mL
Compound 4 was reported as a limit (the forecaster's own chance of this, stated with the estimate: 90%); the middle value is on the limit's open side.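

Compound 4 gives no readable step against compound 1, compound 2 or compound 3, since all four are reported only as a limit: the limit of < 1000 ug/mL in this assay, at which 4 of the 4 values shown sit.

As far as these compounds go, the actual solubility of each compound, and whether changing the group alters it, remains open.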